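A few compounds are considered here, and "the series" means these few. Any claim that something is new, unique, unknown or untested is made for them only; others in the source may bear on it.

Compound 2, `CCOC(=O)C(O)Cn1cnc2c(N)ncnc21`, is measured in a functional assay on HeLa cells (Homo sapiens) for cytotoxicity (a higher number here means that more compound is tolerated, a lower number that less compound is tolerated), only as a limit: compound 2 gives > 400 ug/mL. Compound 1, `Nc1ncnc2c1ncn2CC(O)C(=O)OCCO`, likewise sits at a limit, giving > 400 ug/mL in this assay. The step that the two limits leave unreadable from compound 1 to compound 2 cannot be read because the limit of > 400 ug/mL in this assay, at which 2 of the 2 values shown sit, covers both compounds. Compound 3, `CCCOC(=O)C(O)Cn1cnc2c(N)ncnc21`, differs from compound 2 by methyl in place of hydrogen on a saturated chain carbon, two bonds along the chain from an oxygen next to a carbonyl group. No measured step bears on this change, so nothing shown argues for a shift in tolerated concentration. The expected step of a number no higher from compound 2 to compound 3 (the limit leaves the size open) is none beyond the scatter. Compound 3 is therefore estimated at 400 ug/mL, between 200 ug/mL and 800 ug/mL, most likely reported again as a limit.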

Compound 3, minimum cytotoxic concentration: > 400 ug/mL
Compound 3: no number, only a limit; the forecaster's own chance of this, stated with the estimate: 85%; the middle value lies on the limit itself.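

In this assay, within the data shown here, no step among compound 1, compound 2 and compound 3 can be read: the limit of > 400 ug/mL in this assay, at which 3 of the 3 values shown sit. The compounds shown leave open the concentration at which any of them becomes cytotoxic, and whether the ester chain changes it.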